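The source may hold more compounds than are shown below. What is called first, only, known or untested is meant among the compounds shown, and "the series" means these compounds.

Compound 3 `CC(C)(O)CNc1cc(Oc2ccc(NC(=O)Nc3cccc(C(F)(F)F)c3)cc2)ncn1` gives 40 nM in an assay on isolated protein for inhibition of serine/threonine-protein kinase TNNI3K (Homo sapiens) (on this read-out lower numbers stand for stronger inhibition and higher numbers for weaker inhibition), level with compound 1 `CNc1cc(Oc2ccc(NC(=O)Nc3cccc(C(F)(F)F)c3)cc2)ncn1` at 40 nM, and the two together hold the lowest values of the three; compound 2 `COc1cc(Oc2ccc(NC(=O)Nc3cccc(C(F)(F)F)c3)cc2)ncn1` at 4000 nM stands furthest away, with a 100-fold lower number from compound 2 to compound 3 (2.00 log units; beyond the scatter). Compound 4 `O=C(Nc1ccc(Oc2cc(NCCO)ncn2)cc1)Nc1cccc(C(F)(F)F)c1` differs from compound 3 in one place: hydroxymethyl in place of 1-hydroxy-1-methylethyl on a saturated chain carbon bound to a nitrogen on an aromatic ring. Among the measured compounds shown here, the one measured step that touches this saturated chain carbon is no change at the digits printed from compound 1 to compound 3 (within the scatter), where the whole 1-hydroxy-1-methylethyl group entered without any shift beyond the scatter; the large step of a 100-fold higher number from compound 1 to compound 2 (2.00 log units; beyond the scatter) concerns a different change on the aromatic carbon and does not bear here. Compound 4 is therefore expected to stay at the level of compound 3, with no change at the digits printed from compound 3 to compound 4 (within the scatter). The estimate for compound 4 is 40 nM, within 15 nM to 110 nM.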

Compound 4, half-maximal inhibitory concentration: 32 nM
Compound 4: middle estimate off by 1.3-fold (0.10 log units), on the high side, and the stated range covers the measured number.
By their numbers in this assay, from the lowest: compounds 4, 1 and 3 (each within the scatter of the next); then compound 2.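

In this assay, the shorter 2-hydroxyethyl chain of compound 4 serves as well as the 2-hydroxy-2-methylpropyl chain of compound 3 (a 1.3-fold lower number from compound 3 to compound 4 (0.10 log units; within the scatter)), so the larger group is not required at this position. Hydroxymethyl on the saturated chain carbon also leaves the number level with plain hydrogen (a 1.3-fold lower number from compound 1 to compound 4 (0.10 log units; within the scatter)). The separation from the methoxy compound holds with this chain too (a 130-fold lower number from compound 2 to compound 4 (2.10 log units; beyond the scatter)). No measurement shown explains why these chains are interchangeable. On these data alone, whether a longer chain ending in an amine or a carboxylic acid would also hold this level remains open.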